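The source may hold more compounds than are shown below. What is called first, only, known or untested is meant among the compounds shown, and "the series" means these compounds.

Measured compounds:
- Compound 1 `Cc1cccc(Cn2cc(COc3ccc4c(=O)ccoc4c3)nn2)c1`: 11700 nM
- Compound 2 `O=c1ccoc2cc(OCc3cn(Cc4ccc(Br)cc4)nn3)ccc12`: 37500 nM
- Compound 3 `O=c1ccoc2cc(OCc3cn(Cc4ccc([N+](=O)[O-])cc4)nn3)ccc12`: 19300 nM

Among the compounds with values here, in a functional assay on SW480 cells (Homo sapiens) for cytotoxicity, read by MTT assay, with a stated time of 48 h (on this read-out higher numbers stand for weaker inhibition and lower numbers for stronger inhibition), compound 1 gives the lowest of the three numbers; compound 3 sits nearest to it and compound 2 furthest, with a 3.2-fold higher number from compound 1 to compound 2 (0.51 log units; beyond the scatter) the only step that lies beyond the scatter. Compound 4 `O=c1ccoc2cc(OCc3cn(Cc4ccccc4Br)nn3)ccc12` is not yet measured. It differs from compound 1 in one place: 2-bromophenyl in place of 3-methylphenyl on a saturated chain carbon bound to an aromatic nitrogen. The step that bears most on this change is a 3.2-fold higher number from compound 1 to compound 2 (0.51 log units; beyond the scatter), where a bromine also entered a phenyl on the saturated chain carbon bound to an aromatic nitrogen, though at a different position of the ring. The step of a 1.6-fold higher number from compound 1 to compound 3 (0.22 log units; within the scatter) shows that another swap at that ring stayed within the scatter, so the loss seen with compound 2 is not general. A modest rise in number is therefore expected, as a 1.9-fold higher number from compound 1 to compound 4 (0.27 log units; within the scatter). For compound 4 the estimate in this assay is 22000 nM, with a range from 9000 nM to 50000 nM.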

Compound 4, half-maximal inhibitory concentration: > 100000 nM
Compound 4 was reported as a limit (the forecaster's own chance of this, stated with the estimate: 10%); middle value at least 4.5-fold (0.65 log units) away from the limit.
By their numbers in this assay, from the lowest: compounds 1, 3 and 2 (each within the scatter of the next, the first and the last beyond it). At a limit, above all of these: compound 4.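

In this assay, compound 4 stands apart from the other compounds, as it alone gives a limit of the assay and not a number: the limit of > 100000 nM in this assay, at which 1 of the 4 values shown sits. With bromine on the ring in both compounds, 2-bromophenyl in place of 4-bromophenyl gives an at least 2.6-fold higher number from compound 2 to compound 4 (0.42 log units; beyond the scatter), so the place of the bromine on this ring counts, not only its presence. Within the data shown here, the other two steps, an at least 8.5-fold higher number from compound 1 to compound 4 (0.93 log units; beyond the scatter) and an at least 5.1-fold higher number from compound 3 to compound 4 (0.71 log units; beyond the scatter), each show a larger loss at this ring than any step among the earlier compounds.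

Going by these compounds, the true number for compound 4 stays unknown, so how far these steps really reach remains open. Also open, on these data alone, is how a chlorine, an amine or a carboxylic acid on this ring, or a longer chain in place of the saturated chain carbon, would behave.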